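Piperazinylsulfonyl in place of the sulfonimidoyl group of compound 1

The source may hold more compounds than are shown below. What is called first, only, known or untested is meant among the compounds shown, and "the series" means these compounds.

Compound 1 `CCOC(=O)[C@@H]1CCCN(S(=O)(=O)c2ccc(S(=N)(=O)N(CC)CC)cc2)C1` gives 3600 nM in a functional assay on BXPC-3 cells (Homo sapiens) for inhibition, read by MTT assay, with a stated time of 7 days (on this read-out lower numbers stand for stronger inhibition and higher numbers for weaker inhibition), and holds the second highest of the three numbers measured. Compound 2 `CCN(CC)C(=O)[C@@H]1CCCN(S(=O)(=O)c2ccc(S(=O)(=O)N(CC)CC)cc2)C1` gives 10500 nM in this assay, a higher number than compound 1 and beyond the scatter. Compound 3 `CCC(CC)S(=O)(=O)c1ccc(S(=O)(=O)N2CCC[C@@H](C(=O)N3CCN(c4nc(C(C)C)no4)CC3)C2)cc1` gives 120 nM in this assay, far lower than compound 1 and well beyond the scatter. Compound 4 `CCOC(=O)[C@@H]1CCCN(S(=O)(=O)c2ccc(S(=O)(=O)N3CCNCC3)cc2)C1` is not yet measured; it differs from compound 1 as follows (a group of 9 heavy atoms (4 carbon, 2 nitrogen, 2 oxygen, 1 sulfur; one six-membered non-aromatic ring with 2 hetero atoms) in place of a group of 8 heavy atoms (4 carbon, 2 nitrogen, 1 oxygen, 1 sulfur; no ring), on an aromatic carbon). Within the data shown here, no measured pair shows this change, so its size is unknown. The expected step from compound 1 to compound 4 is a 1.4-fold higher number from compound 1 to compound 4 (0.14 log units; within the scatter), a small loss that may stay within the scatter. Compound 4 is estimated at 5000 nM, ranging from 1500 nM to 16000 nM.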

Compound 4, half-maximal inhibitory concentration: > 30000 nM
Compound 4: no number, only a limit (the forecaster's own chance of this, stated with the estimate: 15%); at least 6.0-fold (0.77 log units) between middle value and limit.
By their numbers in this assay, from the lowest: compound 3; then compound 1; then compound 2. At a limit, above all of these: compound 4.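

Among these compounds, this is the first step that can be read at a single place, the aromatic carbon para to a large group. Putting (piperazin-1-yl)sulfonyl there, with the rest of compound 1 kept, gives an at least 8.3-fold higher number from compound 1 to compound 4 (0.92 log units; beyond the scatter) in this assay, so the group at this position strongly affects the read-out. Compound 4 gives only a limit, not a number, so the step has a lower bound and no full size: the limit of > 30000 nM in this assay, at which 1 of the 4 values shown sits.

The compounds shown do not tell which part of the change carries the loss. Open, on these data alone, is whether (morpholin-4-yl)sulfonyl or (4-methylpiperazin-1-yl)sulfonyl at this position would return to the range of compound 1.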